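Purine ribosides against equilibrative nucleoside transporter binding

The source may hold more compounds than are shown below. What is called first, only, known or untested is meant among the compounds shown, and "the series" means these compounds.

Measured so far:
compound 1 `OC[C@H]1O[C@@H](n2cnc3c(SC4CCCCC4)ncnc32)[C@H](O)[C@@H]1O` — 6310 nM
compound 2 `CCCn1cnc2c(SC(C)C)nc(N)nc21` — 145000 nM
compound 3 `CC(C)Sc1nc(N)nc2c1ncn2[C@@H]1O[C@H](CO)[C@@H](O)[C@H]1O` — 191000 nM

In an assay on isolated protein for binding affinity to Equilibrative nucleoside transporter 1 (Homo sapiens) (on this read-out lower numbers stand for stronger inhibition and higher numbers for weaker inhibition), compound 1 gives the lowest of the three numbers; compound 2 and compound 3 both sit far above it, beyond the scatter. Compound 4 `OC[C@H]1O[C@@H](n2cnc3c(CSc4cccc(Br)c4)ncnc32)[C@H](O)[C@@H]1O` is not yet measured. It differs from compound 1 in one place: ((3-bromophenyl)sulfanyl)methyl in place of cyclohexylsulfanyl on an aromatic carbon. For the measured compounds named here, no measured pair in this set tracks that kind of change, so the expected step rests on the structural change alone. A moderate step toward lower numbers is expected, at most slightly beyond the scatter, since nothing here argues for a large shift either way. Compound 4 is estimated at 3000 nM in this assay, in the range 500 nM to 20000 nM, which would mean an expected step of a 2.1-fold lower number from compound 1 to compound 4 (0.32 log units; beyond the scatter).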

Compound 4, half-maximal inhibitory concentration: 363 nM
Compound 4: the middle estimate sits 8.3-fold (0.92 log units) above what was measured; measured number outside the range, below it.
By their numbers in this assay, from the lowest: compound 4; then compound 1; then compounds 2 and 3 (each within the scatter of the next).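

In this assay, ((3-bromophenyl)sulfanyl)methyl in place of cyclohexylsulfanyl on an aromatic carbon of the shared core gives a 17-fold lower number from compound 1 to compound 4 (1.24 log units; beyond the scatter), so this position admits a larger group carrying an aromatic ring and the read-out moves strongly with what sits there. The change alters the ring type, adds a carbon and brings in bromine all at once, so the step cannot be assigned to any one of these. Nothing available explains the step. Still open, from the compounds shown here alone, is whether (phenylsulfanyl)methyl, lacking the bromine, or a benzylamine at the same place would keep this gain.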